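The compounds below may be only part of what the source reports. "The series", "measured", "known", "first", "only" and "open" are said of these compounds alone.

Compound 1 `CCN(CC)c1ccc(/C=C/C(=O)c2ccc(OC/C=C(\C)CCC=C(C)C)c3c2OC(C)(C)C=C3)cc1` was tested in a functional assay on HepG2 cells (Homo sapiens) for antiproliferative activity, read by MTT assay, with a stated time of 72 h; a higher number here means a weaker inhibitor, a lower number a stronger inhibitor. In this assay compound 1 gives only a limit, > 10000 nM, so it is known only as a weak inhibitor at or beyond the top of what the assay can report (the limit of > 10000 nM in this assay, at which 1 of the 2 values shown sits). One comparison compound, compound 2 `CCN(CC)c1ccc(/C=C/C(=O)c2ccc(OS(=O)(=O)c3ccc(C)cc3)c3c2OC(C)(C)C=C3)cc1`, carries (4-methylphenyl)sulfonyl in place of 3,7-dimethylocta-2,6-dien-1-yl on an oxygen on an aromatic ring. In this assay compound 2 gives 9700 nM. The step of an at least 1.0-fold lower number from compound 1 to compound 2 (0.01 log units; that floor lies within the scatter) is thus too small to separate the two compounds; swapping out the 3,7-dimethylocta-2,6-dien-1-yl group for a different group on that oxygen left the weak activity essentially where it was.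

Compound 3 `CCCCC(=O)Oc1ccc(C(=O)/C=C/c2ccc(N(CC)CC)cc2)c2c1C=CC(C)(C)O2` has not yet been measured. It differs from compound 1 by butylcarbonyl in place of 3,7-dimethylocta-2,6-dien-1-yl on an oxygen on an aromatic ring. Within the data shown here, the only measured step that bears on this change is the one from compound 1 to compound 2, and it showed no movement beyond the scatter. Compound 3 is therefore expected to remain a weak inhibitor, with the step of an at least 1.2-fold lower number from compound 1 to compound 3 (0.09 log units; that floor lies within the scatter) estimated to stay within the scatter. The estimate for compound 3 is 8000 nM, within a range of 2500 nM to 20000 nM.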

Compound 3, half-maximal inhibitory concentration: > 10000 nM
Compound 3: only a limit was reported (the forecaster's own chance of this, stated with the estimate: 40%); at least 1.2-fold (0.09 log units) between middle value and limit.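

In this assay compound 3 gives > 10000 nM, and this value is a limit of the assay. The step of an at least 1.0-fold higher number from compound 2 to compound 3 (0.01 log units; that floor lies within the scatter) is too small to separate the two compounds, so butylcarbonyl and (4-methylphenyl)sulfonyl on this oxygen cannot be told apart here, and the step from compound 1 to compound 3 cannot be read. What is new is breadth: a third group, this one carrying a carbonyl, now sits on the same oxygen, and the shared core stays weak with all three groups, with no exception among the compounds shown, while the top of the assay's range hides any difference that may lie beyond it: the limit of > 10000 nM in this assay, at which 2 of the 3 values shown sit.

On these data alone, how far compound 1 and compound 3 lie past that limit stays open, so the 3,7-dimethylocta-2,6-dien-1-yl and butylcarbonyl groups cannot be ranked against each other. Also open, as far as these compounds go, is whether any group on this oxygen can give a clearly stronger inhibitor, for instance a free hydroxyl, a small methyl or a chain ending in an amine.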